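This account rests on a few compounds, and the source may have more. Where it says the series, first, only, none or still open, it means among the compounds named here.

Measured so far in an assay on isolated protein for binding affinity to 5-hydroxytryptamine receptor 7 (Homo sapiens); a higher number here means a weaker inhibitor, a lower number a stronger inhibitor:
compound 1 `O=C1c2ccccc2CCCN1CCN1CCC(Oc2ccc(F)cc2)CC1`, compound 1 gives 4.47 nM
compound 2 `O=C1c2ccccc2CCCN1CCN1CCC(Oc2ccc(Cl)cc2)CC1`, compound 2 gives 11.8 nM
compound 3 `O=C(c1ccc(F)cc1)C1CCN(CCN2CCCc3ccccc3C2=O)CC1`, compound 3 gives 1.66 nM

Two cores are present. Compound 3 differs from compound 1 by (4-fluorophenyl)carbonyl in place of 4-fluorophenoxy on a saturated ring carbon, a change that moved the number a 2.7-fold lower number from compound 1 to compound 3 (0.43 log units; beyond the scatter). On the core of compound 1, the change chloro in place of fluoro on an aromatic carbon gave a 2.6-fold higher number from compound 1 to compound 2 (0.42 log units; beyond the scatter). Compound 4 `O=C(c1ccc(Cl)cc1)C1CCN(CCN2CCCc3ccccc3C2=O)CC1` carries the same change on the core of compound 3, namely (chloro in place of fluoro on an aromatic carbon); the place of the change is the same in both pairs. Within the data shown here, with only one prior instance of this change, the expectation for compound 4 rests on compound 1 and compound 2 and their step of a 2.6-fold higher number from compound 1 to compound 2 (0.42 log units; beyond the scatter). Compound 4 is therefore estimated at 4.3 nM in this assay, within 2 nM to 10 nM, which would mean an expected step of a 2.6-fold higher number from compound 3 to compound 4 (0.41 log units; beyond the scatter).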

Compound 4, inhibition constant: 2.51 nM
Compound 4: the middle estimate sits 1.7-fold (0.23 log units) above what was measured, within the range that was stated.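

In this assay, chloro in place of fluoro on an aromatic carbon gave a 1.5-fold higher number from compound 3 to compound 4 (0.18 log units; within the scatter), and the step does not differ measurably between the two cores: the same change on two cores in this assay, a 2.6-fold higher number (0.42 log units; beyond the scatter) from compound 1 to compound 2 and a 1.5-fold higher number (0.18 log units; within the scatter) from compound 3 to compound 4, 1.7-fold (0.24 log units) apart, within the scatter of two such steps

(4-Chlorophenyl)carbonyl in place of 4-chlorophenoxy gave a 4.7-fold lower number from compound 2 to compound 4 (0.67 log units; beyond the scatter), whereas (4-chlorophenyl)carbonyl in place of 4-fluorophenoxy gave a 1.8-fold lower number from compound 1 to compound 4 (0.25 log units; within the scatter). The two pairs are consistent with the halogen change carrying over between these cores, but they do not show that it would carry to any other core, and on the core of compound 3 the step alone lies within the scatter.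

On these data alone, what bromo or trifluoromethyl in the same place would give remains open. So does the effect of a longer chain linking the two halves of these molecules.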